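A few compounds are considered here, and "the series" means these few. Any claim that something is new, unique, unknown or untested is made for them only; others in the source may bear on it.

Compound 1, `CN1C(=S)[C@@H](NC(=O)c2nc(Cc3ccccc3)n(CCCC(F)(F)F)n2)COc2ccccc21`, in a toxicity assay on HT-29 cells (Homo sapiens) for cytotoxicity (on this read-out lower numbers stand for higher toxicity in this test and higher numbers for lower toxicity in this test), gives > 100000 nM, a limit of the test.
Compound 2, `CN1C(=S)[C@@H](NC(=O)c2nc(Cc3ccccc3)n(C3CCCCCC3)n2)COc2ccccc21`, in this assay gives > 100000 nM, also a limit.
Compound 3, `CN1C(=S)[C@@H](NC(=O)c2nc(Cc3ccccc3)n(C3COC3)n2)COc2ccccc21`, in this assay gives > 100000 nM, again a limit.

All three measured compounds share one core and differ only in the group on an aromatic nitrogen. None of them yields a number: every value sits at the same limit (the limit of > 100000 nM in this assay, at which 3 of the 3 values shown sit), so the steps between them, a step that the two limits leave unreadable from compound 1 to compound 2, a step that the two limits leave unreadable from compound 1 to compound 3 and a step that the two limits leave unreadable from compound 2 to compound 3, cannot be read in size or direction. Compound 3 therefore stands where the other two stand, at the limit, with nothing to set it apart.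

Compound 4, `CN1C(=S)[C@@H](NC(=O)c2nc(Cc3ccccc3)n(C3CCNCC3)n2)COc2ccccc21`, is the next member of the series, and it differs from compound 3 in one place: piperidin-4-yl in place of oxetan-3-yl on an aromatic nitrogen. No measured step bears readably on this change, since each shown step joins two limits. Among the measured compounds shown here, the only guide is that three different groups at this position all left the read-out at the limit. Compound 4 is accordingly expected to give 100000 nM in this assay, in a range from 30000 nM to 300000 nM, and most likely as a limit again. The step this estimate means, a number no higher from compound 3 to compound 4 (the limit leaves the size open), is expected to be none beyond the scatter.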

Compound 4, half-maximal cytotoxic concentration: > 100000 nM
Compound 4 gave a limit, no number; the forecaster's own chance of this, stated with the estimate: 80%; the middle value sits exactly at the limit.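

Compound 4 sits at the same limit as compound 1, compound 2 and compound 3, so no step among these four can be read in size or direction: the limit of > 100000 nM in this assay, at which 4 of the 4 values shown sit.

The compounds shown leave open whether any group on this aromatic nitrogen would bring this assay to a readable number.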